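The source may report more compounds than this note shows. Statements on the series, on what has been measured and on what is new or still open speak of the compounds shown alone.

Two measured compounds share one core. Compound 1 `Cc1ccc([C@H]2CC(=O)c3ccc(F)cc3O2)cc1` gives 150 nM in an in vitro assay on BTI-TN-5B1-4 cells for inhibition of Amine oxidase [flavin-containing] B (Homo sapiens) (on this read-out lower numbers stand for stronger inhibition and higher numbers for weaker inhibition), and compound 2 `Cc1ccc([C@H]2CC(=O)c3ccc(C)cc3O2)cc1` gives 530 nM. Going by the values given here, compound 2 has the highest of the two numbers; the only measured change, a 3.5-fold higher number from compound 1 to compound 2 (0.55 log units; beyond the scatter), separates it from compound 1. Compound 3 `Cc1ccc2c(c1)O[C@@H](c1ccccc1)CC2=O` is not yet measured. It differs from compound 2 by hydrogen in place of methyl on an aromatic carbon. Among the compounds with values here, no measured step touches this position, so the single known step gives no direct guide and a step within the scatter in either direction is expected for a 1.2-fold lower number from compound 2 to compound 3 (0.07 log units; within the scatter). Compound 3 is therefore estimated at 450 nM, between 150 nM and 1300 nM.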

Compound 3, half-maximal inhibitory concentration: 140 nM
Beside the measured number, compound 3's estimate is 3.2-fold (0.51 log units) above it; the whole stated range lies above it.
By their numbers in this assay, from the lowest: compounds 3 and 1 (each within the scatter of the next); then compound 2.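

In this assay the methyl on this aromatic carbon, para to a large group, is not neutral: hydrogen in its place gives a 3.8-fold lower number from compound 2 to compound 3 (0.58 log units; beyond the scatter) and so the methyl here goes with weaker inhibition. Going by these compounds alone, the earlier step concerned a different aromatic carbon, so this is the first reading at this position. Nothing measured here explains the shift. Going by these compounds, whether a methoxy group, an amine or a longer chain at this position would behave like methyl or like hydrogen remains open. Also open, on these data alone, is whether removing the methyl gives a similar step when fluoro replaces the other methyl of the shared core.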